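The source may hold more compounds than are shown below. What is called first, only, known or untested is meant among the compounds shown, and "the series" means these compounds.

Working notes on the series.

Compound 1 `COc1ccc(-c2noc(CCCCC3CCSS3)n2)cc1OC` is the dimethoxy member of the series. In a functional assay on HT-22 cells (Mus musculus), with a stated time of 24 h (a higher number here means that more compound is needed for the effect, a lower number that less compound is needed), compound 1 gives only a limit, > 10000 nM, so its position on the scale is not fixed by a number; it sits at the limit of > 10000 nM in this assay, at which 1 of the 2 values shown sits. Compound 2 `Oc1ccc(-c2noc(CCCCC3CCSS3)n2)cc1O` is the catechol member, and in this assay compound 2 gives 3630 nM.

The next step keeps the dimethoxy head of compound 1 and opens the ring at the far end of the chain: compound 3 `COc1ccc(-c2noc(CCCCC(S)CCS)n2)cc1OC` differs from compound 1 by a group of 5 heavy atoms (3 carbon, 2 sulfur; no ring) in place of a group of 5 heavy atoms (3 carbon, 2 sulfur; one five-membered non-aromatic ring with 2 hetero atoms), on a saturated chain carbon, four bonds along the chain from an aromatic carbon. Among the compounds with values here, no measured pair shows what this change does, so the size of the step is not known from the data; the opening of the ring is expected to bring a modest shift toward a lower number in this assay, though a step within the scatter, or a second limit, cannot be excluded. The step from compound 1 to compound 3 is estimated as an at least 1.4-fold lower number from compound 1 to compound 3 (0.15 log units; that floor lies within the scatter). Compound 3 is expected to give about 7000 nM in this assay, with a plausible range from 2000 nM to 20000 nM.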

Compound 3, half-maximal effective concentration: > 10000 nM
Compound 3: only a limit was reported; the forecaster's own chance of this, stated with the estimate: 45%; at least 1.4-fold (0.15 log units) between middle value and limit.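

In this assay compound 3 gives only a limit, > 10000 nM. Compound 1 also gives only a limit, so no step can be read between compound 1 and compound 3: the limit of > 10000 nM in this assay, at which 2 of the 3 values shown sit.

The compounds shown leave open whether opening the ring shifts the number at all, and what the 1,3-disulfanylpropyl group would give alongside the catechol head of compound 2.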